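Swapping the Side Chain on a Shared Core

This account rests on a few compounds, and the source may have more. Where it says the series, first, only, none or still open, it means among the compounds named here.

Measured compounds:
Compound 1 `BrCCCOc1c(Br)cc(Br)cc1Oc1ccc(Br)cc1Br` gives 29.9 ug/mL in a functional assay on HL-60 cells (Homo sapiens) for cytotoxicity, read by MTT assay, with a stated time of 24 h; on this read-out higher numbers stand for weaker inhibition and lower numbers for stronger inhibition.
Compound 2 `COc1c(Br)cc(Br)cc1Oc1ccc(Br)cc1Br` gives 28.2 ug/mL in this assay.

Within the data shown here, compound 1 holds the higher of the two numbers, but its only neighbour sits right beside it: a 1.1-fold lower number from compound 1 to compound 2 (0.03 log units; within the scatter). The two values therefore lie within the scatter of each other, and no order can be read from them.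

Compound 3, `C=CCOc1c(Br)cc(Br)cc1Oc1ccc(Br)cc1Br`, is the compound still to be measured. It differs from compound 1 in a single place: vinyl in place of 2-bromoethyl on a saturated chain carbon bound to an oxygen on an aromatic ring. Among the measured compounds shown here, the one measured step that touches this same chain is a 1.1-fold lower number from compound 1 to compound 2 (0.03 log units; within the scatter), and it stayed flat. That step removed a far larger piece of the chain than the present exchange does, and the number barely moved. Because a 1.1-fold lower number from compound 1 to compound 2 (0.03 log units; within the scatter) was within the scatter, a change confined to the same chain is expected to leave the number close to where compound 1 stands.

Compound 3 is therefore estimated to give 28 ug/mL, with an expected range from 14 ug/mL to 56 ug/mL. The expected step of a 1.1-fold lower number from compound 1 to compound 3 (0.03 log units; within the scatter) is thus no change beyond the scatter.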

Compound 3, half-maximal inhibitory concentration: 27.9 ug/mL
Beside the measured number, compound 3's estimate is 1.0-fold (0.00 log units) above it; the measured number falls inside the stated range.
By their numbers in this assay, from the lowest: compounds 3, 2 and 1 (each within the scatter of the next).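

In this assay, this change takes the bromine off the chain and brings in a double bond outside the aromatic rings, yet it gives a 1.1-fold lower number from compound 1 to compound 3 (0.03 log units; within the scatter) and so leaves the number in place. Measured against the other neighbour, putting vinyl in place of hydrogen on the same saturated chain carbon gives a 1.0-fold lower number from compound 2 to compound 3 (0.00 log units; within the scatter), so the chain can also gain a double bond with no shift that can be read. Among the three chains now seen at this position, neither the bromine nor the double bond separates one compound from another, and no measured evidence here offers an explanation for this flat result.

As far as these compounds go, all three side chains are small, carbon-based and uncharged, so it remains open whether an amine, a carboxylic acid or a much longer chain on the same oxygen would move the number beyond the scatter. The compounds also leave open whether replacing one of the bromines on the shared core would matter more than any change to this side chain.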